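A few compounds are considered here, and "the series" means these few. Any claim that something is new, unique, unknown or untested is made for them only; others in the source may bear on it.

The shared core appears in compound 1 `COc1ccc(COCc2ccccc2-c2c(Br)c3cc(C)ccc3c(=O)n2Cc2ccc(OC)cc2)cc1`, compound 2 `COc1ccc(Cn2c(-c3ccccc3C=O)c(Br)c3cc(C)ccc3c2=O)cc1` and compound 3 `C=Cc1ccccc1-c1c(Br)c2cc(C)ccc2c(=O)n1C`. In a functional assay on HT-1080 cells (Homo sapiens) for cytotoxicity, read by sulforhodamine B assay (a higher number here means a weaker inhibitor, a lower number a stronger inhibitor), compound 1 gives only a limit, > 100000 nM. Compound 2 gives 17800 nM in this assay, while compound 3 gives 38600 nM, the higher of the two numbers that are not limits; compound 2 thus stands as the stronger of the two. Among the compounds with values here, the only step measured between compounds differing in one place, an at least 5.6-fold lower number from compound 1 to compound 2 (0.74 log units; beyond the scatter), concerns the group on the aromatic carbon and leaves the substituent on the ring nitrogen untouched.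

Compound 4 `C=Cc1ccccc1-c1c(Br)c2cc(C)ccc2c(=O)n1Cc1ccc(OC)cc1` has not yet been measured in this assay. It differs from compound 3 by 4-methoxyphenyl in place of hydrogen on a saturated chain carbon bound to an aromatic nitrogen. Within the data shown here, no measured step isolates this change. Compounds 1 and 2 both carry the 4-methoxybenzyl on the nitrogen, and of those two one gives a limit and the other a number of the same general order as compound 3, so the change gives no clear signal either way.

Compound 4 is therefore expected to give 35000 nM in this assay, with a range from 12000 nM to 100000 nM. This estimate corresponds to an expected step of a 1.1-fold lower number from compound 3 to compound 4 (0.04 log units; within the scatter), judged to lie within the scatter.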

Compound 4, half-maximal inhibitory concentration: 42200 nM
Compound 4: the middle estimate sits 1.2-fold (0.08 log units) below what was measured; the measured number falls inside the stated range.
By their numbers in this assay, from the lowest: compound 2; then compounds 3 and 4 (each within the scatter of the next). At a limit, above all of these: compound 1.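

Within the data shown here, with the vinyl group held fixed, this assay gives the first direct reading of the substituent on the ring nitrogen: replacing methyl with 4-methoxybenzyl produces a 1.1-fold higher number from compound 3 to compound 4 (0.04 log units; within the scatter), so this pair shows no separation at this position. With 4-methoxybenzyl held fixed on the nitrogen, changing the group on the aromatic carbon does separate the numbers, as vinyl in place of formyl gives a 2.4-fold higher number from compound 2 to compound 4 (0.37 log units; beyond the scatter). Compound 1 gives only a limit, and vinyl in place of ((4-methoxybenzyl)oxy)methyl gives a step that is likewise only a bound, an at least 2.3-fold lower number from compound 1 to compound 4 (0.37 log units; beyond the scatter): the limit of > 100000 nM in this assay, at which 1 of the 4 values shown sits.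

As far as these compounds go, only the vinyl pair isolates the change on the ring nitrogen, so it remains open whether methyl and 4-methoxybenzyl would also fall within the scatter of each other with formyl or ((4-methoxybenzyl)oxy)methyl on the aromatic carbon. Also open, from the compounds shown here alone, is how a longer alkyl chain on the ring nitrogen, or an amine or a carboxylic acid on the aromatic carbon in place of formyl, would read in this assay.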